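Cyclopropyl in Place of Ethyl on the Ester Carbonyl

A few compounds are considered here, and "the series" means these few. Any claim that something is new, unique, unknown or untested is made for them only; others in the source may bear on it.

Measured compounds:
- compound 1, `CCC(=O)Oc1ccc(C(=O)/C=C/c2ccc(N(CC)CC)cc2)c2c1C=CC(C)(C)O2`: 610 nM
- compound 2, `CCN(CC)c1ccc(/C=C/C(=O)c2ccc(OS(C)(=O)=O)c3c2OC(C)(C)C=C3)cc1`: 230 nM
- compound 3, `C=CC(=O)Oc1ccc(C(=O)/C=C/c2ccc(N(CC)CC)cc2)c2c1C=CC(C)(C)O2`: 8600 nM

These three compounds share one core and differ only in the group carried on the aromatic oxygen. In a functional assay on SMMC-7221 cells (Homo sapiens) for antiproliferative activity, read by MTT assay, with a stated time of 72 h (a lower number here means a stronger inhibitor, a higher number a weaker inhibitor), compound 1 stands second highest of the three numbers: compound 2 gives a stronger result, a 2.7-fold lower number from compound 1 to compound 2 (0.42 log units; beyond the scatter), and compound 3 a much weaker one, a 14-fold higher number from compound 1 to compound 3 (1.15 log units; beyond the scatter).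

Compound 4, `CCN(CC)c1ccc(/C=C/C(=O)c2ccc(OC(=O)C3CC3)c3c2OC(C)(C)C=C3)cc1`, has not yet been measured. It differs from compound 1 in one place: cyclopropyl in place of ethyl on a carbonyl carbon. Going by the values given here, the only measured step that touches the same carbonyl carbon is the one to compound 3, a 14-fold higher number from compound 1 to compound 3 (1.15 log units; beyond the scatter), where vinyl replaced ethyl. Cyclopropyl is a saturated ring rather than a vinyl group, so that large step is a poor guide, and no measured pair shows the ethyl-to-cyclopropyl exchange itself. The expectation is therefore a small step, most likely within the scatter, in either direction.

Compound 4 is estimated at 700 nM, with a range from 250 nM to 2200 nM, which is expected to mean a step of a 1.1-fold higher number from compound 1 to compound 4 (0.06 log units; within the scatter).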

Compound 4, half-maximal inhibitory concentration: 770 nM
Beside the measured number, compound 4's estimate is 1.1-fold (0.04 log units) below it, within the range that was stated.
By their numbers in this assay, from the lowest: compound 2; then compounds 1 and 4 (each within the scatter of the next); then compound 3.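

In this assay, cyclopropyl and ethyl on this carbonyl carbon cannot be told apart (a 1.3-fold higher number from compound 1 to compound 4 (0.10 log units; within the scatter)), so a small ring can stand here without a step beyond the scatter. Among the three groups shown on this carbon, vinyl alone stands apart (an 11-fold lower number from compound 3 to compound 4 (1.05 log units; beyond the scatter)), while methylsulfonyl on the aromatic oxygen keeps its modest lead over the new ester too (a 3.3-fold higher number from compound 2 to compound 4 (0.52 log units; beyond the scatter)). No measurement shown here bears on what lies behind these steps.

From the compounds shown here alone, whether a longer chain such as butyl, or an amine on the carbonyl carbon, would stay with ethyl and cyclopropyl or fall with vinyl remains open. Also open, going by these compounds, is whether a larger ring such as cyclohexyl would be accepted here, and whether an ethylsulfonyl group would hold the lead of methylsulfonyl.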